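Aryl in place of benzyl on the sulfonyl sulfur

A few compounds are considered here, and "the series" means these few. Any claim that something is new, unique, unknown or untested is made for them only; others in the source may bear on it.

Compound 1 `COc1cc(OC)c(/C=C(\C(=O)c2ccc(Cl)cc2)S(=O)(=O)Cc2ccc(F)cc2)c(OC)c1` has been measured in a functional assay on DU-145 cells (Homo sapiens) for inhibition, read by trypan blue exclusion, with a stated time of 96 h (a lower number here means a stronger inhibitor of growth, a higher number a weaker inhibitor of growth), where compound 1 gives 25000 nM. Compound 2 `Cc1ccc(S/C(=C/c2ccc(F)cc2C(F)(F)F)C(=O)c2ccc(Br)cc2)cc1` differs from compound 1 in several places at once; in this assay compound 2 gives 25000 nM; the two values are level at the digits shown, within the scatter, so compound 1 stands level with compound 2 and the numbers do not separate them. Compound 3 `COc1cc(OC)c(/C=C(\C(=O)c2ccc(Cl)cc2)S(=O)(=O)c2ccc(Br)cc2)c(OC)c1` is not yet measured. It differs from compound 1 in one place: 4-bromophenyl in place of 4-fluorobenzyl on a sulfonyl sulfur. Among the compounds with values here, no measured pair tracks this change, so there is no step to lean on. Both measured values sit at the same weak level, which gives no hint that a change on the sulfonyl sulfur moves the read-out; the expected step in this assay is no change at the digits printed from compound 1 to compound 3 (within the scatter), none beyond the scatter. Compound 3 is therefore estimated to give 25000 nM in this assay, with a range from 8000 nM to 50000 nM.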

Compound 3, concentration for 50% growth inhibition: > 100000 nM
Compound 3: only a limit was reported (the forecaster's own chance of this, stated with the estimate: 40%); middle value at least 4.0-fold (0.60 log units) from the limit.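

Placing 4-bromophenyl in place of 4-fluorobenzyl on the sulfonyl sulfur gives an at least 4.0-fold higher number from compound 1 to compound 3 (0.60 log units; beyond the scatter) in this assay, the first sign in the series that this position can move the read-out, here towards weaker growth inhibition. Compound 3 gives > 100000 nM, which is a limit of the assay and not a number. The step therefore fixes only a minimum size, and how far compound 3 truly lies from compound 1 stays unknown: the limit of > 100000 nM in this assay, at which 1 of the 3 values shown sits.

The change alters the halogen and removes the benzyl carbon in one move, so the compounds shown leave open which of the two carries the step; 4-fluorophenyl or 4-bromobenzyl on the sulfonyl sulfur would separate them. Also open, going by these compounds, is how a longer chain ending in an amine or a carboxylic acid would read at this position.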